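Working notes on the step from compound 2 to compound 4

The compounds below may be only part of what the source reports. "The series", "measured", "known", "first", "only" and "open" are said of these compounds alone.

Of the compounds shown here, three so far carry a reading in an ADME assay on L1210/0 cells (Mus musculus) for cytotoxicity, with a stated time of 48 h; on this read-out higher numbers stand for weaker inhibition and lower numbers for stronger inhibition. Compound 1 `O=C(/C=C/c1cc(=O)[nH]c(=O)n1COCCO)c1ccccc1` gives 43300 nM. Compound 2 `C=C(Cl)c1cn([C@H]2C[C@H](O)[C@@H](CO)O2)c(=O)[nH]c1=O` gives 1660 nM, the lowest of the two numbers; its nearest neighbour is compound 1, and the gap between the two lies beyond the usual scatter. Compound 3 `Nc1ncnc2c1ncn2[C@@H]1C[C@@H]2COC[C@H]2[C@H]1CO` reaches only > 200000 nM, which is a limit of the assay and not a number, as noted in the limit of > 200000 nM in this assay, at which 1 of the 3 values shown sits.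

Compound 4 `CCC#Cc1cn([C@H]2C[C@H](O)[C@@H](CO)O2)c(=O)[nH]c1=O` has not yet been measured in this assay. It differs from compound 2 in one place: but-1-yn-1-yl in place of 1-chloroethenyl on an aromatic carbon. For the measured compounds named here, no pair of measured compounds differs in a single place, so there is no measured step to lean on; the expectation rests on compound 2 alone and on the exchange of the chloro-bearing alkene for the alkyne chain.

The step from compound 2 to compound 4 is expected to be a modest one toward weaker inhibition, of a size that may or may not clear the scatter, as expressed in a 3.0-fold higher number from compound 2 to compound 4 (0.48 log units; beyond the scatter). For compound 4 in this assay the estimated value is 5000 nM, with a plausible range from 800 nM to 30000 nM.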

Compound 4, half-maximal inhibitory concentration: > 200000 nM
Compound 4: only a limit was reported; the forecaster's own chance of this, stated with the estimate: 10%; at least 40-fold (1.60 log units) between middle value and limit.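

For the compounds shown here, this is the first step that changes one place only: but-1-yn-1-yl in place of 1-chloroethenyl on an aromatic carbon gives an at least 120-fold higher number from compound 2 to compound 4 (2.08 log units; beyond the scatter). In this assay, as far as these compounds go, compound 4 gives > 200000 nM, which is a limit of the assay and not a number, so the true size of the step stays unknown and only its lower bound can be read: the limit of > 200000 nM in this assay, at which 2 of the 4 values shown sit. This position, on a six-membered aromatic ring with 2 nitrogen and two atoms from the ring nitrogen, is therefore not indifferent to its substituent, since this one exchange on an otherwise unchanged core separates a measurable reading from a limit, although a single pair shows this for these two groups alone.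

The pair does not separate the loss of the chlorine-bearing double bond from the arrival of the triple bond or the longer chain, and it gives no cause for the step. From the compounds shown here alone, how an ethynyl group, a vinyl group without chlorine, a bromine atom or an amine would read at this position remains open.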